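The source may report more compounds than this note shows. Statements on the series, on what has been measured and on what is new or still open speak of the compounds shown alone.

Compound 2 (`COC(=O)NC[C@H]1CN(c2ccc(-n3cc(-c4ccccn4)cn3)c(F)c2)C(=O)O1`) stands at the lower end of the two numbers measured in an ADME assay on L02 cells (Homo sapiens) for cytotoxicity, read by MTT assay, with a stated time of 48 h (a lower number here means a stronger inhibitor, a higher number a weaker inhibitor), giving 71 ug/mL. Within the data shown here, compound 1 (`CCC(=O)NC[C@H]1CN(c2ccc(-n3cc(-c4ccccn4)cn3)c(F)c2)C(=O)O1`) gives 204 ug/mL, and the only measured step, a 2.9-fold lower number from compound 1 to compound 2 (0.46 log units; beyond the scatter), comes from putting methoxy in place of ethyl on the carbonyl carbon of the side chain, so compound 2 is the more cytotoxic of the pair by a modest margin.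

Compound 3 (`CCNC(=O)NC[C@H]1CN(c2ccc(-n3cc(-c4ccccn4)cn3)c(F)c2)C(=O)O1`) is the next variation at the same spot: ethylamino in place of methoxy on a carbonyl carbon. Among the measured compounds shown here, the one step on record, a 2.9-fold lower number from compound 1 to compound 2 (0.46 log units; beyond the scatter), touched this carbonyl carbon and produced a modest shift, which shows that the group here can move the number, but neither measured compound carries an ethylamino group, so there is no direct precedent for its direction. For the measured compounds named here, with only this indirect guide, the expected change a 1.5-fold higher number from compound 2 to compound 3 (0.19 log units; within the scatter) is small and may well fall within the scatter of repeated measurements. On that basis compound 3 is estimated to give 110 ug/mL in this assay, with a likely range from 40 ug/mL to 300 ug/mL.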

Compound 3, half-maximal inhibitory concentration: > 400 ug/mL
Compound 3: a limit, no number (the forecaster's own chance of this, stated with the estimate: 15%); middle value at least 3.6-fold (0.56 log units) from the limit.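

In this assay, compound 3 is recorded as a limit of the assay and not as a number: the limit of > 400 ug/mL in this assay, at which 1 of the 3 values shown sits. The earlier compounds shown here showed only that methoxy gave a lower number than ethyl on this carbonyl carbon, whereas ethylamino in place of methoxy gives an at least 5.6-fold higher number from compound 2 to compound 3 (0.75 log units; beyond the scatter), so a change at this spot can also move the number clearly upward, toward a weaker inhibitor. Ethylamino in place of ethyl gives an at least 1.9-fold higher number from compound 1 to compound 3 (0.29 log units; that floor lies within the scatter), so compound 1 and compound 3 cannot be firmly ordered, while compound 2, with its methoxy group, stands apart from both as the strongest inhibitor of the three in this cytotoxicity read-out.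

From the compounds shown here alone, the true value of compound 3 remains unknown, which leaves the full size of both new steps open. Going by these compounds, it is also open whether ethoxy, a bare amino group or a longer chain such as propylamino on the same carbonyl carbon would give a number close to that of compound 2 or would, like ethylamino, reach the limit.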